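The source may hold more compounds than are shown below. What is called first, only, known or untested is meant among the compounds shown, and "the series" means these compounds.

Measured in a functional assay on HeLa cells (Homo sapiens) for cytotoxicity, read by MTT assay, with a stated time of 48 h; a lower number here means a stronger inhibitor, a higher number a weaker inhibitor:
- compound 1 `CC(C)(C)c1ccc(-c2cnc3c(c2)C=CS(=O)(=O)O3)cc1`: 171000 nM
- compound 2 `O=S1(=O)C=Cc2cc(-c3cc(Cl)cc(Cl)c3)cnc2O1`: 4800 nM

Of these two, compound 1 has the higher number at 171000 nM, and compound 2 is lower at 4800 nM, a gap beyond the scatter. Compound 1 is therefore the weaker inhibitor of the pair in this assay.

The next compound is compound 3 `O=S1(=O)C=Cc2cc(-c3ccc(C(F)(F)F)cc3)cnc2O1`, which keeps the shared core of compound 1 and changes one group: trifluoromethyl in place of tert-butyl on an aromatic carbon, para to a large group (trifluoromethyl in place of tert-butyl on an aromatic carbon).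

Within the data shown here, no measured step isolates this change, so the expectation rests on thin evidence. The only other reference point is compound 2 at 4800 nM, which has no tert-butyl and sits well under compound 1. A move towards lower numbers, beyond the scatter, is therefore expected, though the size is uncertain.

The estimated change is an 8.6-fold lower number from compound 1 to compound 3 (0.93 log units; beyond the scatter). For compound 3 the expected value is 20000 nM, with an estimated range of 5000 nM to 90000 nM.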

Compound 3, half-maximal inhibitory concentration: 42000 nM
The estimate for compound 3 lay 2.1-fold (0.32 log units) below the measured number; low and high end bracket the measured number.
By their numbers in this assay, from the lowest: compound 2; then compound 3; then compound 1.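

Working notes on the group para to a large group, on an aromatic carbon of the six-membered aromatic ring of carbon only: in this assay, trifluoromethyl in place of tert-butyl gives a 4.1-fold lower number from compound 1 to compound 3 (0.61 log units; beyond the scatter), the only step so far that isolates a change in one place. This shows that the read-out responds to the group at this position, even though the two groups match in heavy-atom count and neither has a ring, a hydrogen-bond donor, a hydrogen-bond acceptor or a net charge, so those counts alone do not set the number here. No measurement at hand bears on which property of the two groups lies behind the step.

With a single pair, the step gives a direction for this one exchange and no trend across the position. Still open, going by these compounds, is how the number moves with an amine, a carboxylic acid, a methoxy group or a longer alkyl chain at the same place, and whether the same exchange gives a step of similar size on another substitution pattern of this aromatic ring.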